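Three measured compounds and a fourth awaiting measurement

A few compounds are considered here, and "the series" means these few. Any claim that something is new, unique, unknown or untested is made for them only; others in the source may bear on it.

Measured in an assay on isolated protein for inhibition of protein kinase C zeta type (Homo sapiens), with a stated time of 4 min, tested at 62.5 uM; a higher number here means more inhibition at the concentration tested (going by the name of the read-out), a lower number less inhibition:
Compound 1 `CC(C)(C)C1=NN(c2ccc(Br)cc2)C(c2ccc(O)cc2)C1` gives 93.2%.
Compound 2 `CC(C)(C)C1=NN(c2ccc(C(F)(F)F)cc2)C(c2ccc(O)cc2)C1` gives 94.2%.
Compound 3 `Oc1ccc(C2CC(c3cccs3)=NN2c2ccc(Br)cc2)cc1` gives 95.2%.

Compound 3 holds the highest of the three numbers, but its margins to compound 2 and to compound 1 both lie within the scatter, so the three compounds are not separated in this assay. Compound 4 `Oc1ccc(C2CC(c3cccs3)=NN2c2ccc(C(F)(F)F)cc2)cc1` differs from compound 3 in one place: trifluoromethyl in place of bromo on an aromatic carbon. The same change was already measured once, as a number 1 percentage points higher from compound 1 to compound 2 (within the scatter), a step within the scatter. On that single precedent no step beyond the scatter is expected for compound 4, and the estimate is a number 0.2 percentage points lower from compound 3 to compound 4 (within the scatter). Compound 4 is therefore expected to give 95% in this assay, with a range from 88% to 99%.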

Compound 4, a percentage reported as inhibition, at one concentration (the size of the read-out at that concentration, not a potency): 99.4%
Estimate against measurement, compound 4: 4.4 percentage points below, and the stated range ends below it.
By their numbers in this assay, from the lowest: compounds 1, 2, 3 and 4 (each within the scatter of the next).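

In this assay, trifluoromethyl in place of bromo on the aromatic carbon now has a second reading (a number 4.2 percentage points higher from compound 3 to compound 4 (within the scatter)), and it agrees with the first: the same change on two cores in this assay, a number 1 percentage points higher (within the scatter) from compound 1 to compound 2 and a number 4.2 percentage points higher (within the scatter) from compound 3 to compound 4, 3.2 percentage points apart, within the scatter of two such steps.
Thiophen-2-yl in place of tert-butyl also gains a second reading (a number 5.2 percentage points higher from compound 2 to compound 4 (within the scatter)), and that pair agrees as well: the same change on two cores in this assay, a number 2 percentage points higher (within the scatter) from compound 1 to compound 3 and a number 5.2 percentage points higher (within the scatter) from compound 2 to compound 4, 3.2 percentage points apart, within the scatter of two such steps.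
Each change thus holds on a second core, with neither step beyond the scatter.

Going by these compounds, what a carboxylic acid or an amine on this aromatic carbon would give remains open. On these data alone, the read-out at one concentration gives no potency, so any ranking of the four compounds also remains open.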